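The compounds below may be only part of what the source reports. "The series", "measured", "known", "first", "only" and "open" are said of these compounds alone.

In an assay on a protein complex for binding affinity to Neuronal acetylcholine receptor; alpha4/beta2 (Rattus norvegicus) (a lower number here means a stronger inhibitor, a higher number a weaker inhibitor), compound 3 `Clc1ncc(O[C@@H]2CCNC2)cc1Br` gives 94 nM, the highest of the two numbers measured, and its neighbour compound 2 `Cc1cc(O[C@@H]2CCNC2)cnc1Cl` gives 64 nM. Compound 1 `CC(C)N1CCC(Oc2cccnc2)C1` gives > 10000 nM, a limit of this assay and not a number: it sits at the limit of > 10000 nM in this assay, at which 1 of the 3 values shown sits. Among the compounds with values here, the only step measured so far, a 1.5-fold higher number from compound 2 to compound 3 (0.17 log units; within the scatter), stayed within the scatter, so a small group swapped at this aromatic carbon changed little. Compound 4 `Clc1ncc(O[C@@H]2CCNC2)cc1-c1ccncc1` differs from compound 3 by pyridin-4-yl in place of bromo on an aromatic carbon. Within the data shown here, no measured step covers a group of this size, so the expectation is loose: a modest weakening, with wide uncertainty. Compound 4 is therefore estimated at 150 nM in this assay, between 30 nM and 1500 nM, which corresponds to an expected step of a 1.6-fold higher number from compound 3 to compound 4 (0.20 log units; within the scatter).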

Compound 4, half-maximal inhibitory concentration: 65 nM
Estimate against measurement, compound 4: 2.3-fold (0.36 log units) above; measured number inside the range.
By their numbers in this assay, from the lowest: compounds 2, 4 and 3 (each within the scatter of the next). At a limit, above all of these: compound 1.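

In this assay this aromatic carbon takes far more than a small swap: pyridin-4-yl brings 6 heavy atoms and a ring where bromo has 1 heavy atom, yet the result is a 1.4-fold lower number from compound 3 to compound 4 (0.16 log units; within the scatter) and no real change. Set against methyl, the larger group gives a 1.0-fold higher number from compound 2 to compound 4 (0.01 log units; within the scatter) and again no real change. Methyl, bromo and pyridin-4-yl thus all give numbers within the scatter here, so the tolerance extends well beyond small groups.

Going by these compounds, whether an amine, a carboxylic acid or a longer chain would fare the same at this carbon stays open. Nothing available here bears on why the number hardly moves.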